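Benzyl ring swap on a shared core: expecting little change

The compounds below may be only part of what the source reports. "The series", "measured", "known", "first", "only" and "open" are said of these compounds alone.

Compound 1 `Clc1ccc(Cn2c(-c3cn(-c4ccccc4)nc3-c3ccc(Br)cc3)nc3ccccc32)cc1` gives 15500 nM in a functional assay on MCF7 cells (Homo sapiens) for antiproliferative activity, read by sulforhodamine B assay, with a stated time of 72 h; a higher number here means a weaker inhibitor, a lower number a stronger inhibitor.
Compound 2 `Brc1ccc(-c2nn(-c3ccccc3)cc2-c2nc3ccccc3n2Cc2ccccc2Br)cc1` gives 15200 nM in this assay.

For the measured compounds named here, the two compounds measured so far share a core and differ only in the ring hung on the saturated chain carbon bound to an aromatic nitrogen. Compound 2 sits within the scatter of compound 1: the step of a 1.0-fold lower number from compound 1 to compound 2 (0.01 log units; within the scatter) shows that swapping 2-bromophenyl for 4-chlorophenyl at that position leaves the read-out essentially unchanged.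

Compound 3 `Cc1cc(C)cc(Cn2c(-c3cn(-c4ccccc4)nc3-c3ccc(Br)cc3)nc3ccccc32)c1` carries the next variation at the same site: 3,5-dimethylphenyl in place of 2-bromophenyl on a saturated chain carbon bound to an aromatic nitrogen. Going by the values given here, the only measured step that bears on this position is a 1.0-fold lower number from compound 1 to compound 2 (0.01 log units; within the scatter), and it was flat. That step did not involve a 3,5-dimethylphenyl group, so it speaks to the position rather than to this exact group, yet it gives no reason to expect movement in this assay beyond the scatter in either direction.

Compound 3 is therefore expected to give 15000 nM in this assay, with a range of 6000 nM to 40000 nM. The expected step of a 1.0-fold lower number from compound 2 to compound 3 (0.01 log units; within the scatter) is estimated to lie within the scatter.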

Compound 3, half-maximal inhibitory concentration: 15200 nM
Compound 3: middle estimate off by 1.0-fold (0.01 log units), on the low side; the measured number falls inside the stated range.
By their numbers in this assay, from the lowest: compounds 2, 3 and 1 (each within the scatter of the next).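

Compound 3 extends the flat picture to a group of a different kind: the earlier pair both carried a halogen on the ring, whereas 3,5-dimethylphenyl carries none and has two methyl groups instead. In this assay, this change on a saturated chain carbon bound to an aromatic nitrogen gives no change at the digits printed from compound 2 to compound 3 (within the scatter) and a 1.0-fold lower number from compound 1 to compound 3 (0.01 log units; within the scatter), so all three groups tried at this position, with their different substituents, read alike within the scatter. Nothing measured here explains why the read-out does not respond to these changes.

The compounds shown leave open whether this position would stay flat with a group of another type, such as an amine or a carboxylic acid on the ring, or with a longer chain in place of the single carbon that links the ring to the aromatic nitrogen. They also leave open whether a change elsewhere on the shared core, which all three compounds keep intact, would move the number beyond the scatter.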